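The source may report more compounds than this note shows. Statements on the series, on what has been measured and on what is new or still open speak of the compounds shown alone.

Compound 1 `CC/C(=C(/c1ccc(/C=C/C(=O)O)cc1)c1cc2ccccc2[nH]1)c1ccccc1C`, in a functional assay on MCF7 cells (Homo sapiens) for inhibition; a lower number here means a stronger inhibitor, a higher number a weaker inhibitor: 33 nM
Compound 2 `CC/C(=C(/c1ccc(/C=C/C(=O)O)cc1)c1cc2ccccc2[nH]1)c1cccc(C)c1`, in this assay: 140 nM
Compound 3 `CC/C(=C(/c1ccc(/C=C/C(=O)O)cc1)c1cc2ccccc2[nH]1)c1cccc(C(F)(F)F)c1`, in this assay: 325 nM

Among these three, compound 3 stands with the highest number: the steps of a 9.8-fold higher number from compound 1 to compound 3 (0.99 log units; beyond the scatter) and a 2.3-fold higher number from compound 2 to compound 3 (0.37 log units; beyond the scatter) both lie beyond the scatter, so compound 3 is the weakest inhibitor of the three. Compound 4 `CC/C(=C(/c1ccc(/C=C/C(=O)O)cc1)c1cc2ccccc2[nH]1)c1ccc(C#N)cc1` differs from compound 3 in one place: 4-cyanophenyl in place of 3-(trifluoromethyl)phenyl on a double-bonded chain carbon bound to a double-bonded chain carbon and a saturated chain carbon. Among the measured compounds shown here, no measured step places a group at this position of the aryl ring; the steps within that ring, a 4.2-fold higher number from compound 1 to compound 2 (0.63 log units; beyond the scatter) and a 2.3-fold higher number from compound 2 to compound 3 (0.37 log units; beyond the scatter), only show that changes on it shifted this assay by modest amounts. The step of a 1.2-fold higher number from compound 3 to compound 4 (0.09 log units; within the scatter) is therefore expected to be modest, with its direction uncertain. For compound 4 the estimate in this assay is 400 nM, within 120 nM to 1300 nM.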

Compound 4, half-maximal inhibitory concentration: 278 nM
The estimate for compound 4 lay 1.4-fold (0.16 log units) above the measured number; measured number inside the range.
By their numbers in this assay, from the lowest: compound 1; then compounds 2, 4 and 3 (each within the scatter of the next, the first and the last beyond it).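

In this assay, 4-cyanophenyl on this double-bonded chain carbon cannot be told apart from 3-(trifluoromethyl)phenyl, a 1.2-fold lower number from compound 3 to compound 4 (0.07 log units; within the scatter), or from 3-methylphenyl, a 2.0-fold higher number from compound 2 to compound 4 (0.30 log units; within the scatter), even though compounds 2 and 3 themselves differ beyond the scatter. The 2-methylphenyl group keeps a clear edge, with an 8.4-fold higher number from compound 1 to compound 4 (0.93 log units; beyond the scatter). No data given here account for these steps. As far as these compounds go, compound 4 alters both the substituent and where it sits on the aryl ring, and the outcome with 2-cyanophenyl or 3-cyanophenyl at this carbon remains open.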